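The source may report more compounds than this note shows. Statements on the series, on what has been measured and on what is new or still open speak of the compounds shown alone.

In a functional assay on HepG2 cells (Homo sapiens) for antiproliferative activity, read by MTT assay, with a stated time of 48 h (on this read-out lower numbers stand for stronger inhibition and higher numbers for weaker inhibition), the three measured compounds stand as follows:

Compound 1 `COc1cc(-c2nnc(SCC(=O)c3ccc(Br)cc3)n2N)cc(OC)c1OC` gives 92500 nM
Compound 2 `COc1cc(-c2nnc(SCC(=O)c3cccc(Br)c3)n2N)cc(OC)c1OC` gives 56000 nM
Compound 3 `COc1cc(-c2nnc(SCC(=O)c3ccccc3F)n2N)cc(OC)c1OC` gives 22600 nM

The three share one core and differ only in the halogenated phenyl group on the carbonyl carbon. Compound 3 holds the lowest number of the three: a 4.1-fold lower number from compound 1 to compound 3 (0.61 log units; beyond the scatter) and a 2.5-fold lower number from compound 2 to compound 3 (0.39 log units; beyond the scatter) both lie beyond the scatter, whereas a 1.7-fold lower number from compound 1 to compound 2 (0.22 log units; within the scatter) stays within it.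

Compound 4 `COc1cc(-c2nnc(SCC(=O)Nc3ccccc3F)n2N)cc(OC)c1OC` takes the next step from compound 3: (2-fluorophenyl)amino in place of 2-fluorophenyl on a carbonyl carbon. For the measured compounds named here, none of the measured steps bears on this change. Going by the values given here, all three swap one halogenated phenyl for another while keeping the carbonyl linkage as it is; no pair measured here differs in the way compound 3 and compound 4 do. Among the compounds with values here, there is thus no measured step of the same kind to set a direction, and the expectation is a step of no size beyond the scatter, held with a wide range. The expected step is a 1.1-fold higher number from compound 3 to compound 4 (0.04 log units; within the scatter). Compound 4 is accordingly estimated at 25000 nM, with a range from 8000 nM to 80000 nM.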

Compound 4, half-maximal inhibitory concentration: 18700 nM
Estimate against measurement, compound 4: 1.3-fold (0.13 log units) above; measured number inside the range.
By their numbers in this assay, from the lowest: compounds 4 and 3 (each within the scatter of the next); then compounds 2 and 1 (each within the scatter of the next).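

In this assay, the carbonyl carbon takes (2-fluorophenyl)amino in place of 2-fluorophenyl, with its added hydrogen-bond donor, and the number stays within the scatter (a 1.2-fold lower number from compound 3 to compound 4 (0.08 log units; within the scatter)). This is the first exchange shown that alters the link to the ring rather than the halogenated phenyl, and on this single pair it leaves the number unmoved. Compound 4 also stands clear of both bromophenyl compounds (a 3.0-fold lower number from compound 2 to compound 4 (0.48 log units; beyond the scatter); a 4.9-fold lower number from compound 1 to compound 4 (0.69 log units; beyond the scatter)), and nothing measured here accounts for the small size of the step from compound 3.

From the compounds shown here alone, the amino link rests on this one pair, so it stays open whether (3-bromophenyl)amino or (4-bromophenyl)amino would behave likewise. Also open, going by these compounds, is what an ether oxygen or a longer chain would do in the same place.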